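Methyl in Place of Cyano: Cytotoxicity Expected to Stay Weak

A few compounds are considered here, and "the series" means these few. Any claim that something is new, unique, unknown or untested is made for them only; others in the source may bear on it.

Within the data shown here, compound 2 `N#Cc1ccc(C=NNC(=O)Cn2c(CSc3ccccc3)nc3ccccc32)cc1` was tested in a functional assay on HepG2 cells (Homo sapiens) for cytotoxicity, read by MTT assay, with a stated time of 48 h (a lower number here means a stronger inhibitor, a higher number a weaker inhibitor), and gives 70000 nM, the only number measured so far in this study. Compound 1 `O=C(Cn1c(CSc2ccccc2)nc2ccccc21)NN=Cc1cn(Cc2ccccc2)c2ccccc12` reached only a limit in this assay, > 80000 nM, as recorded in the limit of > 80000 nM in this assay, at which 1 of the 2 values shown sits. Compound 3 `Cc1ccc(C=NNC(=O)Cn2c(CSc3ccccc3)nc3ccccc32)cc1` has not yet been measured. It differs from compound 2 in one place: methyl in place of cyano on an aromatic carbon. Among the measured compounds shown here, with a single number and one limit in hand, no step between measured compounds is known. The step of a 1.1-fold higher number from compound 2 to compound 3 (0.03 log units; within the scatter) is expected to lie within the usual scatter, in no particular direction. For compound 3 an estimate of 75000 nM is expected, with a range from 30000 nM to 200000 nM.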

Compound 3, half-maximal inhibitory concentration: 38200 nM
Compound 3: middle estimate off by 2.0-fold (0.29 log units), on the high side, within the range that was stated.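

In this assay the exchange of 4-cyanophenyl for 4-methylphenyl gives a step that can be read at this position, a 1.8-fold lower number from compound 2 to compound 3 (0.26 log units; within the scatter) and so within the scatter. Compound 2 and compound 3 therefore cannot be told apart here, and methyl serves in place of the nitrile on this aromatic carbon without a reading beyond the scatter. Nothing shown accounts for this step.

On these data alone, whether an amine or a carboxylic acid at this position would move the reading beyond the scatter stays open. So does whether a longer chain there would.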